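From a free acid to a chlorophenyl amide

This account rests on a few compounds, and the source may have more. Where it says the series, first, only, none or still open, it means among the compounds named here.

Measured in a functional assay on HO8910 cells (Homo sapiens) for inhibition, read by MTT assay, with a stated time of 24 h, tested at 0.1 ug/mL; on this read-out lower numbers stand for less inhibition of growth and higher numbers for more inhibition of growth at the one concentration tested:
compound 1 `O=C(O)CCCCC(CCSC(=O)c1ccccc1)SC(=O)c1ccccc1`: "not active" (no number reported)
compound 2 `O=C(CCCCC1CCSS1)Nc1ccc([N+](=O)[O-])c(C(F)(F)F)c1`: "not active" (no number reported)
compound 3 `O=C(CCCCC(S)CCS)Nc1cccc2ccccc12`: 0.76%

Compound 1 has no single number on this read-out. It carries only the verbal entry "not active" (no number reported), and compound 2 has the same kind of entry. Compound 3 alone has a figure, so compound 1 cannot be placed on a numerical scale.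

The next structure is compound 4 `O=C(CCCCC(CCSC(=O)c1ccccc1)SC(=O)c1ccccc1)Nc1ccc(Cl)cc1`, which has not yet been measured. The change is (4-chlorophenyl)amino in place of hydroxy on a carbonyl carbon: (4-chlorophenyl)amino takes the place of hydroxy on a carbonyl carbon, turning carboxy into (4-chlorophenyl)carbamoyl.

Within the data shown here, no measured pair isolates this change, so its effect has to be judged indirectly. Compound 2 and compound 3 also have a nitrogen-linked aromatic group on that carbonyl carbon, although the rest of each structure differs from compound 4. With that group, compound 2 gives "not active" (no number reported) and compound 3 gives 0.76%. Neither entry points to appreciable growth inhibition, so no step beyond the usual scatter is expected in this assay, in either direction. For compound 4 the expected value is 3%, with an estimated range of 0% to 12%.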

Compound 4, percent growth inhibition at one concentration: 3.68%
The estimate for compound 4 lay 0.7 percentage points below the measured number; low and high end bracket the measured number.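

In this assay compound 4 gives 3.68% while compound 1 carries only "not active" (no number reported) as its entry, so no step can be read between these two compounds. No supporting evidence bears on this result. The compounds shown leave open how much (4-chlorophenyl)carbamoyl in place of carboxy changes growth inhibition.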